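Swapping isopropyl for 3-hydroxypropyl on compound 2

This account rests on a few compounds, and the source may have more. Where it says the series, first, only, none or still open, it means among the compounds named here.

Compound 1 `CCOC(=O)c1c(C)nc(-c2cccc(C#N)c2)n1C` gives 22100 nM
Compound 2 `CCOC(=O)c1c(C)nc(-c2cccc(C#N)c2)n1OC(C)C` gives 6740 nM

In a functional assay on a cell-free system (plasma, Oryctolagus cuniculus) for inhibition, with stated times of 5 min, 1 min and 6 min (a lower number here means a stronger inhibitor, a higher number a weaker inhibitor), compound 2 holds the lower of the two numbers (6740 nM). Compound 3 `CCOC(=O)c1c(C)nc(-c2cccc(C#N)c2)n1OCCCO` carries 3-hydroxypropyl in place of isopropyl on an oxygen on an aromatic ring. Among the compounds with values here, the one measured step that bears on this is modest: a 3.3-fold lower number from compound 1 to compound 2 (0.52 log units; beyond the scatter) with isopropoxy in place of methyl on an aromatic nitrogen. Within the data shown here, no measured compound carries 3-hydroxypropyl, so the direction stays open. The expected step is small and within the scatter (a 1.2-fold higher number from compound 2 to compound 3 (0.07 log units; within the scatter)). Compound 3 is expected at 8000 nM (estimated range 2500 nM to 25000 nM).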

Compound 3, half-maximal inhibitory concentration: 11400 nM
Compound 3: middle estimate off by 1.4-fold (0.15 log units), on the low side, and the stated range covers the measured number.
By their numbers in this assay, from the lowest: compounds 2, 3 and 1 (each within the scatter of the next, the first and the last beyond it).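

Swapping isopropyl for 3-hydroxypropyl adds a hydrogen-bond donor and acceptor on this oxygen, and in this assay the result is a 1.7-fold higher number from compound 2 to compound 3 (0.23 log units; within the scatter) and so no clear shift. Measured against the methyl on the aromatic nitrogen, the new chain gives a 1.9-fold lower number from compound 1 to compound 3 (0.29 log units; within the scatter), so of the two oxygen-linked chains only the isopropoxy of compound 2 stands beyond the scatter from compound 1. No available evidence accounts for these numbers.

Going by these compounds, whether a longer chain, or an amine or carboxylic acid at the chain end, would move the number beyond the scatter remains open.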